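The compounds below may be only part of what the source reports. "The series", "measured", "known", "first", "only" and "open" are said of these compounds alone.

Of the compounds shown here, three have so far been tested in a toxicity assay on MDCK cells (Canis lupus familiaris) for cytotoxicity, read by crystal violet staining, with a stated time of 48 h; on this read-out lower numbers stand for higher toxicity in this test and higher numbers for lower toxicity in this test. Compound 1 `CCc1ccc(CN(Cc2ccc(F)cc2)Cc2cc3ccc(C)cc3[nH]c2=O)cc1` gives only a limit there, > 33000 nM. Compound 2 `Cc1ccc2cc(CN(Cc3ccc(C(C)(C)C)cc3)C3CCCC3)c(=O)[nH]c2c1` likewise reaches only a limit, > 10000 nM. Compound 3 `COc1ccc(CN(Cc2ccc(C(C)(C)C)cc2)Cc2cc3cc(C)ccc3[nH]c2=O)cc1` also yields only a limit in this assay, > 10000 nM. Compound 3 thus stands where the other two stand: none of the three shows measurable toxicity within the tested range, with two of the three values sitting at the limit of > 10000 nM in this assay, at which 2 of the 3 values shown sit, and one at the limit of > 33000 nM in this assay, at which 1 of the 3 values shown sits.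

Compound 4 `COc1ccc(C(C)N(Cc2ccc(C(C)(C)C)cc2)Cc2cc3cc(C)ccc3[nH]c2=O)cc1Cl` is not yet measured. It differs from compound 3 in one place (1-(3-chloro-4-methoxyphenyl)ethyl in place of 4-methoxybenzyl on an amine nitrogen). Among the compounds with values here, no step between two measured compounds is known here, so the size of this change can only be expected: the step from compound 3 to compound 4 is expected to be modest, a mild shift toward higher toxicity at most, that is a step that the limit leaves unreadable from compound 3 to compound 4. Compound 4 is therefore expected to give about 20000 nM in this assay, between 7000 nM and 50000 nM, and may well return only a limit again.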

Compound 4, half-maximal cytotoxic concentration: > 10000 nM
Compound 4: a limit, no number (the forecaster's own chance of this, stated with the estimate: 70%); the middle value is on the limit's open side.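

No step can be read from compound 3 to compound 4, because each gives only a limit and no number: the limit of > 10000 nM in this assay, at which 3 of the 4 values shown sit.

The compounds shown leave open at what concentration, if any, they harm the cells, and whether 1-(3-chloro-4-methoxyphenyl)ethyl in place of 4-methoxybenzyl changes toxicity at all.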